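Cyclopropyl in Place of Isopropyl on the Aromatic Amine

The source may report more compounds than this note shows. Statements on the series, on what has been measured and on what is new or still open speak of the compounds shown alone.

Compound 2 `CCOC(=O)/C=N/c1cnc(Nc2ccc(S(N)(=O)=O)cc2)nc1NC(C)C` gives > 100000 nM in a functional assay on HT-29 cells (Homo sapiens) for antiproliferative activity, read by MTT assay (a lower number here means a stronger inhibitor, a higher number a weaker inhibitor), which is a limit of the assay rather than a measured number (the limit of > 100000 nM in this assay, at which 1 of the 3 values shown sits). Compound 1 `CCOC(=O)/C=N/c1cnc(Nc2ccc(S(N)(=O)=O)cc2)nc1NC1CCCC1` gives 23600 nM, and the step of an at least 4.2-fold higher number from compound 1 to compound 2 (0.62 log units; beyond the scatter) shows that exchanging cyclopentyl for isopropyl weakened the inhibitor. Compound 3 `CC(C)Nc1nc(Nc2ccc(S(N)(=O)=O)cc2)ncc1/N=C/c1ccccc1` gives 98200 nM, and the step of an at least 1.0-fold lower number from compound 2 to compound 3 (0.00 log units; that floor lies within the scatter) sits at its floor. Compound 4 `CCOC(=O)/C=N/c1cnc(Nc2ccc(S(N)(=O)=O)cc2)nc1NC1CC1` differs from compound 2 by cyclopropyl in place of isopropyl on a nitrogen on an aromatic ring. Among the compounds with values here, only the step from compound 1 to compound 2 concerns a ring in this place, and cyclopropyl carries a three-membered ring where cyclopentyl carried a larger one, so compound 4 is expected to move little, a number no higher from compound 2 to compound 4 (the limit leaves the size open), with a fair chance of another limit. Compound 4 is therefore estimated at 100000 nM, between 30000 nM and 300000 nM.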

Compound 4, half-maximal inhibitory concentration: > 100000 nM
Compound 4: only a limit was reported (the forecaster's own chance of this, stated with the estimate: 55%); the middle value sits exactly at the limit.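

Compound 4 gives a limit of the assay, not a number, and the step from compound 2 cannot be read because both compounds stop at that limit: the limit of > 100000 nM in this assay, at which 2 of the 4 values shown sit.

A ring on this nitrogen is therefore not enough by itself: cyclopropyl in place of cyclopentyl gives an at least 4.2-fold higher number from compound 1 to compound 4 (0.62 log units; beyond the scatter). Among the compounds shown that carry ethoxycarbonyl, only compound 1, with cyclopentyl, gives a measured number.

As far as these compounds go, whether cyclohexyl or a longer chain such as n-butyl on this nitrogen would give a lower number than compound 1 stays open. So does the reading for cyclobutyl.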